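Carboxymethyl replaces cyclohexyl on the amide nitrogen

This account rests on a few compounds, and the source may have more. Where it says the series, first, only, none or still open, it means among the compounds named here.

Measured compounds:
compound 1, `Nc1nn(CC(=O)NCc2ccco2)c2nc(-c3ccccc3)cc(C(F)(F)F)c12`, 5000 nM
compound 2, `Nc1nn(CC(=O)NC2CCCCC2)c2nc(-c3ccccc3)cc(C(F)(F)F)c12`, 5200 nM

In a functional assay on MCF7 cells (Homo sapiens) for cytotoxicity, read by MTT assay, with a stated time of 24 h (a higher number here means a weaker inhibitor, a lower number a stronger inhibitor), compound 2 stands highest of the two numbers, though its nearest neighbour, compound 1, lies within the scatter of it, so the two cannot be ordered. Compound 3, `Nc1nn(CC(=O)NCC(=O)O)c2nc(-c3ccccc3)cc(C(F)(F)F)c12`, alters the group on the amide-type nitrogen: carboxymethyl in place of cyclohexyl on an amide-type nitrogen. Going by the values given here, the only measured step at that position, a 1.0-fold higher number from compound 1 to compound 2 (0.02 log units; within the scatter), was within the scatter. Compound 3 is therefore expected to show a 1.2-fold higher number from compound 2 to compound 3 (0.06 log units; within the scatter), with no step beyond the scatter. Compound 3 is estimated at 6000 nM, within a range from 2500 nM to 15000 nM.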

Compound 3, half-maximal inhibitory concentration: 21200 nM
Beside the measured number, compound 3's estimate is 3.5-fold (0.55 log units) below it; measured number outside the range, above it.
By their numbers in this assay, from the lowest: compounds 1 and 2 (each within the scatter of the next); then compound 3.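

In this assay, the group on the amide-type nitrogen does move the number: carboxymethyl gives a 4.1-fold higher number from compound 2 to compound 3 (0.61 log units; beyond the scatter) and a 4.2-fold higher number from compound 1 to compound 3 (0.63 log units; beyond the scatter) in the same direction. Cyclohexyl and (furan-2-yl)methyl had stayed within the scatter of each other, so only this third group shows that the position is not indifferent to what it carries. No measurement shown here accounts for the shift. The compounds leave open whether a methyl ester of the carboxymethyl group would behave like compound 3. They also leave open how a longer chain ending in a carboxylic acid, or in an amine, would read.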